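The source may report more compounds than this note shows. Statements on the series, on what has been measured and on what is new or still open speak of the compounds shown alone.

Compound 1 `C=CCn1c(=O)n([C@@H]2O[C@H](CO)[C@H]3OC(C)(CCC(=O)O)O[C@H]32)c2nc(N)nc(O)c21`, compound 2 `C=CCn1c(=O)n([C@@H]2O[C@H](CO)[C@H]3OC(C)(CCC(=O)NC)O[C@H]32)c2nc(N)nc(O)c21` and compound 3 `C=CCn1c(=O)n([C@@H]2O[C@H](CO)[C@H]3OC(=O)O[C@H]32)c2nc(N)nc(O)c21` share one core and differ only in the group that bridges the two ring oxygens of the sugar part. In a functional assay on YAC-1 cells (Mus musculus) (a lower number here means a smaller maximal response, a higher number a larger maximal response), compound 1 gives 0%, compound 2 gives 0% and compound 3 gives 90%. Compound 2 therefore stands level with compound 1 at the bottom of the three numbers, while compound 3 lies a long way higher. Among the measured compounds shown here, the one step measured within this set, no change at the digits printed from compound 1 to compound 2 (within the scatter), shows that exchanging the group on the carbonyl carbon of the side chain moved nothing beyond the scatter.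

Compound 4 `C=CCn1c(=O)n([C@@H]2O[C@H](CO)[C@H]3OC(C)(CCC(=O)OCC)O[C@H]32)c2nc(N)nc(O)c21` is not yet measured. It differs from compound 2 by ethoxy in place of methylamino on a carbonyl carbon. This is the same carbonyl carbon on the same chain that was already changed without effect from compound 1 to compound 2, so the expectation for this assay is no change beyond the scatter, an expected step of no change at the digits printed from compound 2 to compound 4 (within the scatter). Compound 4 is thus estimated at 0%, within a range of 0% to 15%.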

Compound 4, largest response reached (reported as maximal response), in percent of the reference or control that the assay uses: 19%
Estimate against measurement, compound 4: 19 percentage points below; the whole stated range lies below it.
By their numbers in this assay, from the lowest: compounds 1 and 2 (each within the scatter of the next); then compound 4; then compound 3.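

In this assay, ethoxy in place of methylamino on a carbonyl carbon gives a number 19 percentage points higher from compound 2 to compound 4 (beyond the scatter) and ethyl in place of hydrogen on an oxygen next to a carbonyl group gives a number 19 percentage points higher from compound 1 to compound 4 (beyond the scatter) as well. Among the compounds shown here, the earlier step showed no movement at this carbonyl carbon, so this result is the first sign that the group there can matter, with 2-(ethoxycarbonyl)ethyl alone among the three side chains of this kind lifting the response off the level shared by compound 1 and compound 2. Nothing available explains why ethoxy parts from hydroxy and methylamino here.

On these data alone, it remains open whether a longer alkoxy group such as propoxy or butoxy on the same carbonyl carbon would raise the response further. Equally open, as far as these compounds go, is whether a tertiary amide such as dimethylamino would behave like ethoxy or like methylamino.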